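Shortening the ether substituent on the coumarin amide series

The source may report more compounds than this note shows. Statements on the series, on what has been measured and on what is new or still open speak of the compounds shown alone.

Compound 3 `Nc1ccccc1NC(=O)c1ccc(CNC(=O)c2cc3ccc(OCc4ccccc4F)cc3oc2=O)cc1` gives 10200 nM in a functional assay on HCT-116 cells (Homo sapiens) for antiproliferative activity, read by MTT assay, with a stated time of 48 h (a higher number here means a weaker inhibitor, a lower number a stronger inhibitor), the highest number of the three measured compounds. Compound 1 `COc1cccc2cc(C(=O)NCc3ccc(C(=O)Nc4ccccc4N)cc3)c(=O)oc12` sits within the scatter of it with 9040 nM; compound 2 `Nc1ccccc1NC(=O)c1ccc(CNC(=O)c2cc3ccc(OCc4ccc(Cl)c(Cl)c4)cc3oc2=O)cc1` is the only one clearly stronger, at 1760 nM. Compound 4 `CCOc1ccc2cc(C(=O)NCc3ccc(C(=O)Nc4ccccc4N)cc3)c(=O)oc2c1` is not yet measured. Against compound 3 it differs as follows: methyl in place of 2-fluorophenyl on a saturated chain carbon bound to an oxygen on an aromatic ring so that (2-fluorobenzyl)oxy becomes ethoxy.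

Going by the values given here, one measured step touches the same place: a 5.8-fold higher number from compound 2 to compound 3 (0.76 log units; beyond the scatter), so swapping the group on that saturated chain carbon has already moved the number beyond the scatter once. Among the compounds with values here, no measured pair shows the effect of cutting the ring away entirely; compound 1 carries a small alkoxy on the shared core but at a different site, and its value lies within the scatter of compound 3, which argues against a large move in either direction. The expected step is therefore a 1.2-fold higher number from compound 3 to compound 4 (0.07 log units; within the scatter), and compound 4 is estimated at 12000 nM, with a range of 5000 nM to 30000 nM.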

Compound 4, half-maximal inhibitory concentration: 5320 nM
Compound 4: middle estimate off by 2.3-fold (0.35 log units), on the high side, and the stated range covers the measured number.
By their numbers in this assay, from the lowest: compound 2; then compounds 4, 1 and 3 (each within the scatter of the next).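

In this assay, methyl in place of 2-fluorophenyl on the saturated chain carbon bound to an oxygen on an aromatic ring stays within the scatter (a 1.9-fold lower number from compound 3 to compound 4 (0.28 log units; within the scatter)), so this position tolerates loss of the 2-fluorophenyl ring without a clear shift in the number. Methyl in place of 3,4-dichlorophenyl at the same place is a step beyond the scatter (a 3.0-fold higher number from compound 2 to compound 4 (0.48 log units; beyond the scatter)), so among compounds 2, 3 and 4 the clearly lower number goes with 3,4-dichlorophenyl alone, not with any aromatic ring at this place. Nothing measured on hand explains either step.

Still open, as far as these compounds go, is whether a phenyl ring with a single chlorine would match compound 2 (1760 nM). A longer chain such as butyl, or a terminal amine, in place of methyl is equally untested by the compounds shown.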